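Fluoro in place of hydrogen on the phenyl of compound 1

The compounds below may be only part of what the source reports. "The series", "measured", "known", "first", "only" and "open" are said of these compounds alone.

Measured compounds:
compound 1, `N#Cc1c(-c2ccccc2)nc2c(c(-c3ccccc3)nn2-c2ccccc2)c1-c1ccc(O)cc1`, 26100 nM
compound 2, `N#Cc1c(-c2cccs2)nc2c(c(-c3ccccc3)nn2-c2ccccc2)c1-c1ccc(O)cc1`, 34200 nM
compound 3, `COc1cc(-c2c(C#N)c(-c3ccco3)nc3c2c(-c2ccccc2)nn3-c2ccccc2)ccc1O`, 35300 nM

Of the compounds shown here, three share one core and have been tested in a functional assay on MV4-11 cells (Homo sapiens) for antiproliferative activity, read by resazurin assay, with a stated time of 72 h; on this read-out higher numbers stand for weaker inhibition and lower numbers for stronger inhibition. Compound 1 gives 26100 nM, the lowest of the three numbers, but its gaps to compound 2 and compound 3 are both within the usual scatter, so no order among them can be claimed. Among the compounds with values here, the one single-point step among them, a 1.3-fold higher number from compound 1 to compound 2 (0.12 log units; within the scatter), shows that swapping one aromatic ring for another at that position leaves the read-out essentially unchanged.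

Compound 4, `N#Cc1c(-c2ccc(F)cc2)nc2c(c(-c3ccccc3)nn2-c2ccccc2)c1-c1ccc(O)cc1`, is not yet measured. It differs from compound 1 in one place: fluoro in place of hydrogen on an aromatic carbon. Within the data shown here, no measured step involves a fluoro group, so the only guide is the step from compound 1 to compound 2, which changed the same ring far more drastically and still stayed within the scatter. A smaller edit on that same ring is therefore expected to move the number little, in no clear direction.

For compound 4 in this assay the expected value is 24000 nM, with a likely range from 10000 nM to 55000 nM, which means an expected step of a 1.1-fold lower number from compound 1 to compound 4 (0.04 log units; within the scatter).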

Compound 4, half-maximal inhibitory concentration: 11600 nM
Compound 4: middle estimate off by 2.1-fold (0.32 log units), on the high side; the measured number falls inside the stated range.
By their numbers in this assay, from the lowest: compound 4; then compounds 1, 2 and 3 (each within the scatter of the next).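

In this assay, within the data shown here, the change from phenyl to 4-fluorophenyl gives a 2.3-fold lower number from compound 1 to compound 4 (0.35 log units; beyond the scatter), the first step on this ring that lies beyond the scatter. The earlier step of a 1.3-fold higher number from compound 1 to compound 2 (0.12 log units; within the scatter) lay within the scatter and made this ring look free to vary, yet a single fluoro, para to a large group, shifts the number more than replacing phenyl with thiophen-2-yl did; the comparison with the thiophene compound, a 2.9-fold lower number from compound 2 to compound 4 (0.47 log units; beyond the scatter), points the same way, and both steps are modest. Nothing available explains how the fluoro produces this shift.

A single substituent at a single place cannot show whether the gain belongs to fluoro in particular or would also come with chloro, trifluoromethyl or an amine in the same place. From the compounds shown here alone, whether a fluoro on the other phenyl rings of the shared core would move the number at all also remains open. Going by these compounds, compound 4 gives 11600 nM, and whether further changes could lower that number is equally open.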